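Series notes: acetamido in place of (propylcarbonyl)oxy

This account rests on a few compounds, and the source may have more. Where it says the series, first, only, none or still open, it means among the compounds named here.

Compound 1 `CCCC(=O)OC1CCC(CN2CCN(c3cc(=O)c4cc(C(F)(F)F)cc([N+](=O)[O-])c4s3)CC2)CC1` has been measured in an ADME assay on Vero cells (Chlorocebus sabaeus) for cytotoxicity, read by MTT assay, with a stated time of 48 h; a higher number here means a weaker inhibitor, a lower number a stronger inhibitor. In this assay compound 1 returns only a limit, > 64 ug/mL, so its place among real numbers cannot be fixed. Compound 2 `CC(C)S(=O)(=O)OC1CCC(CN2CCN(c3cc(=O)c4cc(C(F)(F)F)cc([N+](=O)[O-])c4s3)CC2)CC1` likewise sits at a limit in this assay, giving > 64 ug/mL. Compound 3 `O=C(OC1CCC(CN2CCN(c3cc(=O)c4cc(C(F)(F)F)cc([N+](=O)[O-])c4s3)CC2)CC1)c1ccco1` gives > 64 ug/mL in this assay, again a limit. The three measured steps, a step that the two limits leave unreadable from compound 1 to compound 2, a step that the two limits leave unreadable from compound 1 to compound 3 and a step that the two limits leave unreadable from compound 2 to compound 3, are all unreadable in size because of the limit of > 64 ug/mL in this assay, at which 3 of the 3 values shown sit.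

Compound 4 `CC(=O)NC1CCC(CN2CCN(c3cc(=O)c4cc(C(F)(F)F)cc([N+](=O)[O-])c4s3)CC2)CC1` has not yet been measured. It differs from compound 1 by acetamido in place of (propylcarbonyl)oxy on a saturated ring carbon. For the measured compounds named here, none of the measured steps involves this group or this kind of change; each shows only that exchanging the groups on the oxygen on the saturated carbon left the value at the limit. On that basis no step beyond the scatter is expected in this assay, and the expected step is a step that the limit leaves unreadable from compound 1 to compound 4. Compound 4 is expected to give about 80 ug/mL, within 40 ug/mL to 200 ug/mL, most likely reported once more as a limit rather than a number.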

Compound 4, half-maximal inhibitory concentration: > 64 ug/mL
Compound 4: no number, only a limit; the forecaster's own chance of this, stated with the estimate: 85%; the middle value lies beyond the limit too.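

In this assay compound 4 adds no readable step to compound 1, compound 2 or compound 3, because the results are limits and not numbers: the limit of > 64 ug/mL in this assay, at which 4 of the 4 values shown sit. The compounds shown leave open where any of the four would fall as a real number, and whether acetamido in place of (propylcarbonyl)oxy shifts the value at all.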